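This account rests on a few compounds, and the source may have more. Where it says the series, first, only, none or still open, it means among the compounds named here.

Measured compounds: compound 1 `COc1cccc(Nc2sc3ccccc3c2C#N)c1` with 81%, compound 2 `CC(=O)N(c1ccc(O)cc1)c1sc2ccccc2c1C#N` with 36%, compound 3 `N#Cc1c(Nc2ccccc2)sc2ccccc12` with 81%, all in a functional assay on HUVEC cells (Homo sapiens), read by fluorescence and microscopy, with a stated time of 6 h, tested at 10 uM; a higher number here means a weaker effect of the compound at the concentration tested, a lower number a stronger effect.

Compound 3 stands level with compound 1 at the digits printed; together they are the highest of the three numbers, and compound 2 lies far below. Compound 4 `COc1ccc(Nc2sc3ccccc3c2C#N)cc1` differs from compound 3 by methoxy in place of hydrogen on an aromatic carbon. Among the measured compounds shown here, the one measured step that bears on it is no change at the digits printed from compound 1 to compound 3 (within the scatter), where a methoxy group on the same aromatic ring was removed without effect. On that basis no step beyond the scatter is expected in this assay; the expected step is a number 1 percentage points lower from compound 3 to compound 4 (within the scatter). Compound 4 is therefore estimated at 80%, with a range from 65% to 92%.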

Compound 4, a percentage reported as activity, at one concentration (the size of the read-out at that concentration, not a potency): 57%
Compound 4: the middle estimate sits 23 percentage points above what was measured; the measured number lies below the stated range.
By their numbers in this assay, from the lowest: compound 2; then compound 4; then compounds 1 and 3 (each within the scatter of the next).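

In this assay, methoxy on an aromatic carbon para to a large group gives a number 24 percentage points lower from compound 3 to compound 4 (beyond the scatter), so a change at this place does move the read-out. Compound 1 carries its methoxy elsewhere on that ring, and removing it gave no change at the digits printed from compound 1 to compound 3 (within the scatter), so among these compounds the outcome depends on where methoxy stands. Nothing available here explains this difference.

The compounds shown leave open whether an amine, a chlorine atom or a longer chain such as ethoxy at this place would lower the number further.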